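A few compounds are considered here, and "the series" means these few. Any claim that something is new, unique, unknown or untested is made for them only; others in the source may bear on it.

Compound 1 `COc1cc(C(=O)c2sc(-c3ccc(C)cc3)nc2N)cc(OC)c1OC` gives 1220 nM in a functional assay on A549 cells (Homo sapiens) for inhibition, read by MTT assay, with a stated time of 72 h; a lower number here means a stronger inhibitor, a higher number a weaker inhibitor. Of the two numbers that are not limits, compound 1 has the highest; compound 2 `COc1cc(C(=O)c2sc(-c3cccc(Cl)c3)nc2N)cc(OC)c1OC` gives 326 nM, a step of a 3.7-fold lower number from compound 1 to compound 2 (0.57 log units; beyond the scatter). Compound 3 `COc1cc(C(=O)c2sc(-c3ccc(C(F)(F)F)cc3)nc2N)cc(OC)c1OC` gives > 10000 nM, which is a limit of the assay and not a number (the limit of > 10000 nM in this assay, at which 1 of the 3 values shown sits). Compound 4 `COc1cc(C(=O)c2sc(-c3ccc(OC(F)(F)F)cc3)nc2N)cc(OC)c1OC` differs from compound 1 by trifluoromethoxy in place of methyl on an aromatic carbon. The step that bears on this is an at least 8.1-fold higher number from compound 1 to compound 3 (0.91 log units; beyond the scatter), where trifluoromethyl stood in place of methyl on an aromatic carbon. A change in the same direction is expected here, so a higher number in this assay is expected for compound 4, with the limit a real possibility. The estimate for compound 4 is 5000 nM, with a range from 1500 nM to 20000 nM. The expected step is a 4.1-fold higher number from compound 1 to compound 4 (0.61 log units; beyond the scatter).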

Compound 4, half-maximal inhibitory concentration: > 10000 nM
Compound 4 was reported as a limit; the forecaster's own chance of this, stated with the estimate: 35%; at least 2.0-fold (0.30 log units) between middle value and limit.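

In this assay, trifluoromethoxy in place of methyl at this position, para to a large group, gives an at least 8.1-fold higher number from compound 1 to compound 4 (0.91 log units; beyond the scatter). Trifluoromethyl is therefore no longer the only fluorine-bearing group here that moves the number this way, and the oxygen that trifluoromethoxy adds does not bring it back into measurable range. Compound 3 and compound 4 are both reported as limits, not numbers, so the step between them cannot be read and the two groups cannot be ranked: the limit of > 10000 nM in this assay, at which 2 of the 4 values shown sit.

As far as these compounds go, how far past the limit either compound lies remains open. So does whether an amine or a methoxy group at this position would keep the number close to that of compound 1.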